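The source may hold more compounds than are shown below. What is called first, only, known or untested is meant among the compounds shown, and "the series" means these compounds.

In a functional assay on PC-3 cells (Homo sapiens) for inhibition, read by MTT assay, with a stated time of 72 h (a lower number here means a stronger inhibitor, a higher number a weaker inhibitor), compound 1 (`C#CCSc1nc(NCCC(C)C)c2ccncc2n1`) reads > 80000 nM, which is a limit of the assay. Compound 2 (`C#CCSc1nc(NCCC#N)c2ccncc2n1`) reads > 80000 nM, also a limit and not a number. Compound 3 (`C#CCSc1nc(Nc2ccc(F)cc2)c2ccncc2n1`) gives 17300 nM. Compound 4 (`C#CCSc1nc(Nc2ccc(Cl)cc2)c2ccncc2n1`) differs from compound 2 as follows: 4-chlorophenyl in place of 2-cyanoethyl on a nitrogen on an aromatic ring. Among the measured compounds shown here, two measured steps bear on this change, an at least 4.6-fold lower number from compound 2 to compound 3 (0.66 log units; beyond the scatter) and an at least 4.6-fold lower number from compound 1 to compound 3 (0.66 log units; beyond the scatter), and both start from a limit. Compound 3 carries 4-fluorophenyl on the same nitrogen where compound 4 carries 4-chlorophenyl. Given an at least 4.6-fold lower number from compound 2 to compound 3 (0.66 log units; beyond the scatter), a step of similar size toward a lower number is expected in this assay. The expected step is an at least 5.3-fold lower number from compound 2 to compound 4 (0.72 log units; beyond the scatter). The estimate for compound 4 is 15000 nM, with an expected range of 6000 nM to 40000 nM.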

Compound 4, half-maximal inhibitory concentration: 19000 nM
Compound 4: the middle estimate sits 1.3-fold (0.10 log units) below what was measured, within the range that was stated.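

In this assay, chloro in place of fluoro on an aromatic carbon gives a 1.1-fold higher number from compound 3 to compound 4 (0.04 log units; within the scatter), so the two cannot be told apart here. A second 4-halophenyl group on this nitrogen also reads lower than both chains, with an at least 4.2-fold lower number from compound 2 to compound 4 (0.62 log units; beyond the scatter) and an at least 4.2-fold lower number from compound 1 to compound 4 (0.62 log units; beyond the scatter). These two steps are lower bounds, not sizes, because compound 1 and compound 2 each read at a limit: the limit of > 80000 nM in this assay, at which 2 of the 4 values shown sit.

From the compounds shown here alone, how an unsubstituted phenyl or a benzyl on the same nitrogen would read remains open. So does the true gap between the chains and the 4-halophenyl groups.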